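A few compounds are considered here, and "the series" means these few. Any claim that something is new, unique, unknown or untested is made for them only; others in the source may bear on it.

Measured compounds:
compound 1, `CCN(Cc1cncs1)C(=O)COc1ccc(C)cc1`, 1100 nM
compound 2, `CCN(Cc1cccs1)C(=O)COc1ccccc1`, 1400 nM

In an assay on HEK293 cells for agonist activity at transient receptor potential cation channel subfamily M member 8 (Homo sapiens), read by fluorescence and calcium flux, with a stated time of 15 min (a higher number here means that more compound is needed for the effect, a lower number that less compound is needed), compound 1 gives 1100 nM and compound 2 gives 1400 nM. Among the measured compounds shown here, these two numbers lie within the usual scatter of repeated measurements of each other, so the data do not set compound 1 ahead of or behind compound 2; compound 1 simply stands at one of two close values, and no step between the two is resolved. Compound 3, `CCN(Cc1cn[nH]c1)C(=O)COc1ccc(C)cc1`, has not yet been measured in this assay. It differs from compound 1 in one place: 1H-pyrazol-4-yl in place of 1,3-thiazol-5-yl on a saturated chain carbon bound to an amide-type nitrogen. The leaving group and the entering group are each a five-membered aromatic ring with 2 hetero atoms, but the entering ring carries 1 hydrogen-bond donor where the leaving ring carried none. For the measured compounds named here, no measured pair shows this change, so its size is not known from the data. The expected step is a 1.8-fold higher number from compound 1 to compound 3 (0.26 log units; within the scatter), a modest move toward a higher number, possibly no larger than the scatter. Compound 3 is accordingly expected to give 2000 nM in this assay, within a range of 700 nM to 6000 nM.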

Compound 3, half-maximal effective concentration: "active" (no number reported)
Compound 3: no number reported, and the estimate cannot be compared.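

In this assay, among the compounds shown here, compound 3 is reported only as active, with no number, so no step from compound 1 to compound 3 can be read. The compounds shown leave open how far 1H-pyrazol-4-yl in place of 1,3-thiazol-5-yl shifts the concentration needed. Nothing shown offers an explanation for this result.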